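Furan-3-yl for Phenyl on a Nucleoside Core

A few compounds are considered here, and "the series" means these few. Any claim that something is new, unique, unknown or untested is made for them only; others in the source may bear on it.

compound 1: `Nc1nc2c(c(-c3ccccc3)cn2[C@@H]2O[C@H](CO)[C@@H](O)[C@H]2O)c(=O)[nH]1` — > 20000 nM
compound 2: `COc1ncnc2c1c(-c1ccsc1)cn2[C@@H]1O[C@H](CO)[C@@H](O)[C@H]1O` — 120 nM

Of the compounds shown here, two have been measured in a functional assay on HCT-116 cells (Homo sapiens), read by MTT assay, with a stated time of 72 h; on this read-out higher numbers stand for weaker inhibition and lower numbers for stronger inhibition. Compound 1 `Nc1nc2c(c(-c3ccccc3)cn2[C@@H]2O[C@H](CO)[C@@H](O)[C@H]2O)c(=O)[nH]1` returns > 20000 nM, a limit rather than a number. Compound 1 therefore sits at the limit of > 20000 nM in this assay, at which 1 of the 2 values shown sits. Compound 2 `COc1ncnc2c1c(-c1ccsc1)cn2[C@@H]1O[C@H](CO)[C@@H](O)[C@H]1O`, built on a different core, gives 120 nM in this assay. Compound 3 `Nc1nc2c(c(-c3ccoc3)cn2[C@@H]2O[C@H](CO)[C@@H](O)[C@H]2O)c(=O)[nH]1` differs from compound 1 by furan-3-yl in place of phenyl on an aromatic carbon. Among the compounds with values here, no measured pair shows a change of this kind, and compound 1 itself offers only a limit. For compound 3 the expected step is a step that the limit leaves unreadable from compound 1 to compound 3, nothing beyond the scatter. Compound 3 is estimated at 25000 nM, between 8000 nM and 80000 nM, most likely reported again as a limit.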

Compound 3, half-maximal inhibitory concentration: 14200 nM
Compound 3: the middle estimate sits 1.8-fold (0.25 log units) above what was measured; low and high end bracket the measured number.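

In this assay, furan-3-yl in place of phenyl on this aromatic carbon gives an at least 1.4-fold lower number from compound 1 to compound 3 (0.14 log units; that floor lies within the scatter). Compound 3, at 14200 nM, thus gives the core of compound 1 its first actual number, so this position tolerates a five-membered aromatic ring with an oxygen in it without loss of the measurable read-out. The value of compound 1 is a limit, so the true size of the step stays unknown: the limit of > 20000 nM in this assay, at which 1 of the 3 values shown sits.

The compounds shown leave open how a pyridin-3-yl ring or an aminomethyl group on this aromatic carbon would read. They also leave open whether any other group here would give a step clearly beyond the scatter.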